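The compounds below may be only part of what the source reports. "The series", "measured", "known", "first", "only" and "open" are said of these compounds alone.

Measured so far:
Compound 1 `COC(=O)c1c(Nc2ccccc2)sc(C(=O)c2ccc(C)cc2)c1C`: 9.35%
Compound 2 `COc1ccc(C(=O)c2sc(Nc3ccccc3)c(C(=O)O)c2C)cc1`: 59.5%

In a functional assay, with a stated time of 150 min, tested at 30 ug/mL (on this read-out higher numbers stand for a stronger effect at the one concentration tested and lower numbers for a weaker effect), compound 2 gives the higher of the two numbers; compound 1, a structure with changes in more than one place, gives a number far lower, beyond the scatter. Compound 3 `Cc1ccc(C(=O)c2sc(Nc3ccccc3)c(C(=O)O)c2C)cc1` keeps the core of compound 2 and differs only by methyl in place of methoxy on an aromatic carbon. For the measured compounds named here, no measured pair shows this exact change on its own, so the expectation rests on little. Compound 1, which also carries the methyl group, gives only 9.35% in this assay, so a drop is expected from compound 2 to compound 3, a number 21.5 percentage points lower from compound 2 to compound 3 (beyond the scatter). Compound 3 is estimated at 38%, with a range from 10% to 65%.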

Compound 3, a percentage reported as activity, at one concentration (the size of the read-out at that concentration, not a potency): 5.13%
Estimate against measurement, compound 3: 32.9 percentage points above, outside the stated range (below it).
By their numbers in this assay, from the lowest: compounds 3 and 1 (each within the scatter of the next); then compound 2.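

On the shared core, methyl in place of methoxy at this position, para to a large group, is enough on its own to make a large difference (a number 54.4 percentage points lower from compound 2 to compound 3 (beyond the scatter)). With the 4-methylphenyl group in place, replacing the ester methyl with hydrogen changes little (a number 4.2 percentage points lower from compound 1 to compound 3 (within the scatter)). Nothing available explains the large step.

On these data alone, it remains open how a hydroxyl, an ethoxy or a chlorine at this position would compare with methoxy. As far as these compounds go, the methyl ester carrying the 4-methoxyphenyl group also remains open.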